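The compounds below may be only part of what the source reports. "The series", "measured", "known", "first", "only" and "open" are said of these compounds alone.

Two compounds with a shared core have numbers in an ADME assay on HEp-2 cells (Homo sapiens) for cytotoxicity; a lower number here means that less compound is tolerated, a higher number that more compound is tolerated. There compound 1 `CC(=O)NCc1ccc2c(c1)nc(Cn1c(=O)n(C(C)C)c3ccccc31)n2CCC(C)C` gives 178000 nM, while compound 2 `CC(C)CCn1c(Cn2c(=O)n(C(C)C)c3ccccc32)nc2ccc(CN)cc21` gives 28100 nM. Compound 2 thus has the lower number of the two, by a margin beyond the usual scatter, so less of it is tolerated. Still unmeasured is compound 3 `CC(C)CCn1c(Cn2c(=O)n(C(C)C)c3ccccc32)nc2ccc(C(N)=O)cc21`, which carries carbamoyl in place of aminomethyl on an aromatic carbon. For the measured compounds named here, no measured pair shows this change directly, so the expectation rests on the two values alone. Compound 1, which also carries no aminomethyl, gives 178000 nM, and this points upward from compound 2. An upward step beyond the scatter is expected, estimated as a 3.2-fold higher number from compound 2 to compound 3 (0.51 log units; beyond the scatter) in this assay. The expected value for compound 3 is 90000 nM, with an estimated range of 30000 nM to 270000 nM.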

Compound 3, half-maximal cytotoxic concentration: 49900 nM
For compound 3 the middle estimate is 1.8-fold (0.26 log units) above the measured one; measured number inside the range.
By their numbers in this assay, from the lowest: compounds 2 and 3 (each within the scatter of the next); then compound 1.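

In this assay, carbamoyl in place of aminomethyl on this aromatic carbon gives a 1.8-fold higher number from compound 2 to compound 3 (0.25 log units; within the scatter), so the two groups cannot be told apart here, although they differ in heavy atoms and carbamoyl adds a double bond outside the aromatic rings. A change at this position therefore need not move the number beyond the scatter, even though the acetylated aminomethyl side chain of compound 1 stands apart from both at 178000 nM. Nothing available explains this outcome.

From the compounds shown here alone, it remains open whether a carboxylic acid, a nitrile or a longer aminoalkyl chain on this aromatic carbon would stay level with compound 2 and compound 3 or approach compound 1. The shared core offers no test of whether the same change behaves alike with a different chain in place of the isopropyl group.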